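A few compounds are considered here, and "the series" means these few. Any claim that something is new, unique, unknown or untested is made for them only; others in the source may bear on it.

Compound 1 `CCCOC(=O)C1=C(C)NC(=O)NC1c1cccs1` gives 32% in an assay on membranes from HeLa cells for displacement of a labelled ligand from adenosine receptor A3 (Homo sapiens), read by scintillation counting, with a stated time of 180 min, tested at 1 uM; on this read-out lower numbers stand for less inhibition and higher numbers for more inhibition at the one concentration tested (going by the name of the read-out).
Compound 2 `CC1=C(C(=O)OC(C)(C)C)C(c2cccs2)NC(=O)N1` gives 7%.
Compound 3 `CC1=C(C(=O)OC(C)(C)C)C(c2cccs2)NC(=O)N1C` gives 22%.

Compound 2 stands lowest of the three numbers. Its nearest neighbour is compound 3, and the gap is a number 15 percentage points higher from compound 2 to compound 3 (beyond the scatter), a step beyond the scatter. The furthest is compound 1, with a number 25 percentage points lower from compound 1 to compound 2 (beyond the scatter) separating the two in the other direction, also beyond the scatter.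

Compound 4 `CCNC(=O)C1=C(C)NC(=O)NC1c1cccs1` has not yet been measured. It differs from compound 2 at one place: ethylamino in place of tert-butoxy on a carbonyl carbon. Among the measured compounds shown here, no measured step exchanges an oxygen substituent on this carbonyl carbon for a nitrogen one, so the only step that bears on the change at this position is the one from compound 1 to compound 2, which shows that what sits on this carbonyl carbon can shift the read-out by a modest but clear amount. The step from compound 2 to compound 3 concerns a different position and speaks only to how far the numbers in this series can move. Because a number 25 percentage points lower from compound 1 to compound 2 (beyond the scatter) was seen when the group on this carbonyl carbon was changed, a step of comparable size upward is expected for compound 4, namely a number 13 percentage points higher from compound 2 to compound 4 (beyond the scatter). The estimate for compound 4 is 20%, with a range from 2% to 42%.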

Compound 4, a percentage reported as inhibition, at one concentration (the size of the read-out at that concentration, not a potency): 4%
Estimate against measurement, compound 4: 16 percentage points above, and the stated range covers the measured number.
By their numbers in this assay, from the lowest: compounds 4 and 2 (each within the scatter of the next); then compounds 3 and 1 (each within the scatter of the next).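

In this assay ethylamino, the only nitrogen group shown on this carbonyl carbon, cannot be told apart from tert-butoxy, with a number 3 percentage points lower from compound 2 to compound 4 (within the scatter) even though this exchange puts nitrogen in place of oxygen on the carbonyl carbon and brings in a hydrogen-bond donor. Against propoxy the same exchange does register, with a number 28 percentage points lower from compound 1 to compound 4 (beyond the scatter) on an otherwise shared core, so among compounds 1, 2 and 4 the higher number goes with propoxy alone, while tert-butoxy and ethylamino stay together whichever atom joins them to the carbonyl carbon. The evidence at hand offers no explanation for how these three groups fall.

From the compounds shown here alone, whether propylamino, which would keep the propyl chain of compound 1 but carry nitrogen in place of oxygen, would stay with compound 1 or fall with compound 4 remains open, and with it how far the chain and the joining atom each count. Also open, going by these compounds, are how a carboxylic acid or a longer amine chain on this carbonyl carbon would read, and whether methyl on the amide-type nitrogen in the ring would move compound 4 as it moved compound 2.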